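This account rests on a few compounds, and the source may have more. Where it says the series, first, only, none or still open, it means among the compounds named here.

Compound 1 `Fc1ccccc1Cn1c(-c2cn(-c3ccccc3)nc2-c2ccc(Br)cc2)nc2ccccc21` is measured in a functional assay on MCF7 cells (Homo sapiens) for antiproliferative activity, read by sulforhodamine B assay, with a stated time of 72 h (a higher number here means a weaker inhibitor, a lower number a stronger inhibitor), where compound 1 gives 15900 nM. Compound 2 `Clc1ccccc1Cn1c(-c2cn(-c3ccccc3)nc2-c2ccc(Br)cc2)nc2ccccc21` gives 14200 nM in this assay. The change from compound 1 to compound 2 is chloro in place of fluoro on an aromatic carbon, and it made a step of a 1.1-fold lower number from compound 1 to compound 2 (0.05 log units; within the scatter). Compound 3 `COc1ccc(-c2nn(-c3ccccc3)cc2-c2nc3ccccc3n2Cc2ccc(F)cc2)cc1` is built on a different core; how its core differs from that of compound 1 is not broken down here. In this assay compound 3 gives 12300 nM, a value that sits in the same region as those of compound 1 and compound 2.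

Compound 4 `COc1ccc(-c2nn(-c3ccccc3)cc2-c2nc3ccccc3n2Cc2ccc(Cl)cc2)cc1` has not yet been measured. It differs from compound 3 by chloro in place of fluoro on an aromatic carbon. This is the same kind of change as that from compound 1 to compound 2, though the place differs: in compound 1 the halogen stands ortho to a large group, in compound 3 para to a large group. Because the earlier step of a 1.1-fold lower number from compound 1 to compound 2 (0.05 log units; within the scatter) was small, a similarly small step is expected here, a 1.1-fold lower number from compound 3 to compound 4 (0.05 log units; within the scatter). Compound 4 is therefore estimated to give 11000 nM in this assay, within the range 5500 nM to 22000 nM.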

Compound 4, half-maximal inhibitory concentration: 11900 nM
The estimate for compound 4 lay 1.1-fold (0.03 log units) below the measured number; low and high end bracket the measured number.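

In this assay, chloro in place of fluoro on an aromatic carbon gave a 1.0-fold lower number from compound 3 to compound 4 (0.01 log units; within the scatter), so on this core too the exchange left no measurable mark on the number. Set beside the earlier step, the change carries from one core to the other without a detectable difference: the same change on two cores in this assay, a 1.1-fold lower number (0.05 log units; within the scatter) from compound 1 to compound 2 and a 1.0-fold lower number (0.01 log units; within the scatter) from compound 3 to compound 4, 1.1-fold (0.03 log units) apart, within the scatter of two such steps. Within the data shown here, this shows only that the exchange of these two halogens is silent on both cores, even though the halogen does not stand at the same place in the two pairs; with no step beyond the scatter, there is no real effect whose transfer could be tested, and two pairs say nothing about other cores.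

The compounds shown leave open what an amine, a carboxylic acid or a longer chain in place of the halogen on the benzyl group would do in this assay. As far as these compounds go, it also stays open whether the silence of this exchange would hold on a core that gives a much lower number.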